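Three weakly cytotoxic analogues and a dimethoxy variant

This account rests on a few compounds, and the source may have more. Where it says the series, first, only, none or still open, it means among the compounds named here.

Of the compounds shown here, three have been measured in an ADME assay on Vero cells (Chlorocebus sabaeus) for cytotoxicity, read by MTT assay, tested at 50 uM; on this read-out lower numbers stand for a stronger effect and higher numbers for a weaker effect at the one concentration tested. Within the data shown here, compound 1 `CSc1ccc(C(=O)/C(=C/c2cc3ccccc3s2)c2ccc(Cl)c(Cl)c2)cc1` gives 91.6%, and compound 2 `CSc1ccc(C(=O)/C(=C/c2ccccn2)c2ccc(Cl)c(Cl)c2)cc1` gives 93.6%; the only step recorded between measured compounds is a number 2 percentage points higher from compound 1 to compound 2 (within the scatter), which leaves the read-out essentially unchanged. Compound 3 `CCOC(=O)C(C(=O)c1ccc(OC)cc1)C(NC(C)=O)c1ccc(C(C)(C)C)cc1` gives 92.3% in this assay, a number that sits alongside those of compound 1 and compound 2, with both gaps inside the usual scatter, so all three show only a weak effect at the concentration tested.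

Compound 4 `CCOC(=O)C(C(=O)c1ccc(OC)cc1)C(NC(C)=O)c1ccc(OC)c(OC)c1` differs from compound 3 in one place: 3,4-dimethoxyphenyl in place of 4-(tert-butyl)phenyl on a saturated chain carbon bound to an amide-type nitrogen and a saturated chain carbon. Among the measured compounds shown here, no measured step involves this change or this part of the structure; the one recorded step concerns another group on another core and was itself within the scatter. The three numbers cluster closely, and nothing in the data points to a departure. Compound 4 is therefore expected to give about 92% in this assay, estimated to lie between 80% and 100%. The expected change is a number 0.3 percentage points lower from compound 3 to compound 4 (within the scatter), no step beyond the scatter.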

Compound 4, a percentage reported as activity, at one concentration (the size of the read-out at that concentration, not a potency): 96.7%
For compound 4 the middle estimate is 4.7 percentage points below the measured one; low and high end bracket the measured number.
By their numbers in this assay, from the lowest: compounds 1, 3, 2 and 4 (each within the scatter of the next).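

In this assay, replacing 4-(tert-butyl)phenyl with 3,4-dimethoxyphenyl gives a number 4.4 percentage points higher from compound 3 to compound 4 (within the scatter), the first step recorded at this saturated chain carbon bound to an amide-type nitrogen and a saturated chain carbon. An all-carbon group thus gives way to one with oxygen atoms and hydrogen-bond acceptors, at the same heavy-atom count, without a change in the read-out beyond the scatter at the one concentration tested. Nothing available explains why the read-out holds for this pair.

From the compounds shown here alone, whether an amine or a carboxylic acid in place of 3,4-dimethoxyphenyl on this carbon would move the read-out beyond the scatter remains open. The compounds shown also leave open how the other parts of the shared core of compound 3 and compound 4 respond to change.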